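Tert-butyl for propyl on the fused core

A few compounds are considered here, and "the series" means these few. Any claim that something is new, unique, unknown or untested is made for them only; others in the source may bear on it.

Compound 1 `CCc1cnc2c(C#N)c(N3CCC(c4ccccc4)CC3)ccn12` gives 501 nM in a functional assay on CHO cells for positive allosteric modulation of metabotropic glutamate receptor 2 (Homo sapiens), read by GTPgammaS binding, with a stated time of 30 min; a higher number here means that more compound is needed for the effect, a lower number that less compound is needed.
Compound 2 `CCCc1nnc2c(C#N)c(N3CCC(c4ccccc4)CC3)ccn12` gives 299 nM in this assay.
Compound 3 `N#Cc1c(N2CCC(c3ccccc3)CC2)ccn2c(CC(F)(F)F)cnc12` gives 125 nM in this assay.

Compound 2 stands second highest of the three numbers in this assay; compound 1 lies a step away that is within the scatter, whereas compound 3 sits beyond it with the lower number. Compound 4 `CC(C)(C)c1nnc2c(C#N)c(N3CCC(c4ccccc4)CC3)ccn12` differs from compound 2 by tert-butyl in place of propyl on an aromatic carbon. Within the data shown here, the only measured step in the set, a 4.0-fold lower number from compound 1 to compound 3 (0.60 log units; beyond the scatter), concerns trifluoromethyl in place of methyl on a saturated chain carbon bound to an aromatic carbon and so bears only loosely on an exchange of one alkyl for another on the ring carbon. Nothing measured speaks to branching or to a fourth carbon at this place. Among the measured compounds shown here, with no step of the same kind to lean on, the expected change in this assay is none beyond the scatter, an estimated 1.2-fold lower number from compound 2 to compound 4 (0.08 log units; within the scatter). Compound 4 is therefore estimated at 250 nM, with a range from 100 nM to 700 nM; the width allows for the shift seen between compound 1 and compound 3, which shows that changes at this part of the core can move the read-out.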

Compound 4, half-maximal effective concentration: 1230 nM
Compound 4: the middle estimate sits 4.9-fold (0.69 log units) below what was measured; measured number above the stated range.
By their numbers in this assay, from the lowest: compound 3; then compounds 2 and 1 (each within the scatter of the next); then compound 4.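

Exchanging propyl for tert-butyl on an aromatic carbon between two ring nitrogen atoms gives, in this assay, a 4.1-fold higher number from compound 2 to compound 4 (0.61 log units; beyond the scatter), so this place on the shared core does not accept every alkyl group alike. Among these compounds, the one earlier step lowered the number and concerned the end of a chain, whereas this is the first reading of an alkyl exchange on the ring carbon itself, and here the number rises. Among the compounds shown here, nothing at hand gives a reason for the rise, and the single step cannot separate branching from the change from 3 to 4 carbon atoms.

A straight butyl chain or an isobutyl group on this carbon would help tell those two apart, since either keeps the 4 carbon atoms of tert-butyl while changing the branching. Also open, going by these compounds, is whether a methyl group or a cyclopropyl ring here stays close to compound 2 at 299 nM, and whether tert-butyl in place of the ethyl group of compound 1 moves the number the same way on the core of that compound.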